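Chain shortening in two hydrazide series against K562 cells

The source may hold more compounds than are shown below. What is called first, only, known or untested is meant among the compounds shown, and "the series" means these compounds.

Measured compounds:
compound 1, `CCCCCCCCCCCCCCNNC(=O)COC`, 66200 nM
compound 2, `CCCCCCCCCCNNC(=O)COC`, 167000 nM
compound 3, `CCCCCCCCCCCC/C=C/N(NC(=O)COC)C(=O)OC(C)(C)C`, 41400 nM

Of the compounds shown here, three have been tested in a functional assay on K562 cells (Homo sapiens) for antiproliferative activity, read by resazurin assay, with a stated time of 72 h; on this read-out higher numbers stand for weaker inhibition of growth and lower numbers for stronger inhibition of growth. Compound 1 and compound 2 share one core; compound 3 carries a different core, and the difference between the two cores is not broken down here. Within the first pair the change is hydrogen in place of butyl on a saturated chain carbon, ten or more bonds along the chain from an amine nitrogen, and it made a step of a 2.5-fold higher number from compound 1 to compound 2 (0.40 log units; beyond the scatter). Compound 3 gives the lowest of the three numbers in this assay, although its gap to compound 1 lies within the scatter.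

Compound 4, `CCCCCCCC/C=C/N(NC(=O)COC)C(=O)OC(C)(C)C`, has not yet been measured. It differs from compound 3 by hydrogen in place of butyl on a saturated chain carbon, eight bonds along the chain from a double-bonded chain carbon. This is the same kind of change as that from compound 1 to compound 2, but the surroundings differ: in the first pair the carbon is placed relative to an amine nitrogen, here relative to a double-bonded chain carbon, as the two counted differences show. Since the earlier step was a 2.5-fold higher number from compound 1 to compound 2 (0.40 log units; beyond the scatter), a comparable weakening is expected for compound 4, as a 2.4-fold higher number from compound 3 to compound 4 (0.38 log units; beyond the scatter). Compound 4 is therefore estimated at 100000 nM, between 50000 nM and 200000 nM.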

Compound 4, concentration for 50% growth inhibition: 45000 nM
Estimate against measurement, compound 4: 2.2-fold (0.35 log units) above; measured number below the stated range.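

In this assay, hydrogen in place of butyl on the core of compound 3 gives a 1.1-fold higher number from compound 3 to compound 4 (0.04 log units; within the scatter), so on this core the change has no effect that can be told from the scatter. Set beside the earlier step on the other core, the two steps cannot be told apart: the same change on two cores in this assay, a 2.5-fold higher number (0.40 log units; beyond the scatter) from compound 1 to compound 2 and a 1.1-fold higher number (0.04 log units; within the scatter) from compound 3 to compound 4, 2.3-fold (0.37 log units) apart, within the scatter of two such steps. The step beyond the scatter on the core of compound 1 is thus not matched by one on the core of compound 3, but this does not show that the two cores respond differently, nor that the change carries over at a fixed size, and a single pair on each core settles neither.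

The compounds shown leave open whether a longer chain, or a chain ending in an amine or a carboxylic acid, would separate the two cores. They also leave open what the difference between the cores contributes by itself, as no pair shown joins one core to the other through a change in one place.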